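Swapping an amide for a tert-butyl ester in a bile acid receptor series

The source may report more compounds than this note shows. Statements on the series, on what has been measured and on what is new or still open speak of the compounds shown alone.

Measured compounds:
- compound 1, `COC(=O)/C=C/c1cccc(N(Cc2ccc(/C=C/c3cccc(F)c3)cc2)C(=O)C2CCCCC2)c1`: 86 nM
- compound 2, `CCOc1cccc(-c2ccc(CN(C(=O)C3CCCCC3)c3cccc(/C=C/C(=O)OC)c3)cc2)c1`: 147 nM
- compound 3, `CC(C)(C)OC(=O)/C=C/c1ccc(CN(C(=O)C2CCCCC2)c2cccc(/C=C/C(N)=O)c2)cc1`: > 1000 nM

All three compounds share a core built around an amide nitrogen carrying a cyclohexylcarbonyl group and two aromatic arms, and all were tested in an assay on isolated protein with Bile acid receptor (Homo sapiens) as the target; on this read-out higher numbers stand for an effect only at larger amounts of compound and lower numbers for an effect already at smaller amounts. Compound 1 gives 86 nM. Going by the values given here, compound 2 gives 147 nM; the one measured step, a 1.7-fold higher number from compound 1 to compound 2 (0.23 log units; within the scatter), changes only a substituent on one arm. Compound 3 differs in more than one place from either, and in this assay compound 3 reaches only a limit, > 1000 nM, so no number is known for it; this is the line (the limit of > 1000 nM in this assay, at which 1 of the 3 values shown sits).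

The unmeasured compound 4, `CC(C)(C)OC(=O)/C=C/c1ccc(CN(C(=O)C2CCCCC2)c2cccc(/C=C/C(=O)OC(C)(C)C)c2)cc1`, comes from compound 3 through (tert-butoxy in place of amino on a carbonyl carbon). Among the compounds with values here, no measured step covers this exchange, so its size cannot be read from the data. Compounds 1 and 2, which carry a methyl ester rather than an amide at that end, both show values well inside the measured range, while compound 3, with the amide, does not. On that basis compound 4 is expected to move in the direction of a lower number, an at least 2.0-fold lower number from compound 3 to compound 4 (0.30 log units; that floor lies within the scatter), though with wide uncertainty. The estimate for compound 4 is 500 nM, with a range from 100 nM to 3000 nM.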

Compound 4, half-maximal effective concentration: > 1000 nM
Compound 4 ended at the assay's limit (the forecaster's own chance of this, stated with the estimate: 30%); middle value at least 2.0-fold (0.30 log units) from the limit.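

Compound 3 and compound 4 both end at a limit rather than at a number in this assay, so the exchange of amino for tert-butoxy yields no readable step: the limit of > 1000 nM in this assay, at which 2 of the 4 values shown sit. The compounds shown leave open how far past that limit each compound lies, and whether this exchange changes the value at all.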